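A few compounds are considered here, and "the series" means these few. Any claim that something is new, unique, unknown or untested is made for them only; others in the source may bear on it.

Compound 1 `Cc1ccccc1-n1nncc1CN1C(=O)C2(C(C#N)=C(N)Oc3c2c2nc4ccccc4nc2c2ccccc32)c2ccccc21` gives > 50000 nM, a limit of the assay.
Compound 2 `N#CC1=C(N)Oc2c(c3nc4ccccc4nc3c3ccccc23)C12C(=O)N(Cc1cnnn1-c1cccc(Cl)c1)c1ccccc12` gives 35200 nM.
Compound 3 `CCOc1ccccc1-n1nncc1CN1C(=O)C2(C(C#N)=C(N)Oc3c2c2nc4ccccc4nc2c2ccccc32)c2ccccc21` gives > 50000 nM, a limit of the assay.

In an ADME assay on L02 cells (Homo sapiens) for antiproliferative activity, read by MTT assay, with a stated time of 48 h (on this read-out higher numbers stand for weaker inhibition and lower numbers for stronger inhibition), compound 1 stands only at a limit, not at a number. Compound 3 sits at the same limit. The picture is of weak inhibition throughout (the limit of > 50000 nM in this assay, at which 2 of the 3 values shown sit). Compound 4 `N#CC1=C(N)Oc2c(c3nc4ccccc4nc3c3ccccc23)C12C(=O)N(Cc1cnnn1-c1ccc([N+](=O)[O-])cc1)c1ccccc12` differs from compound 1 in one place: 4-nitrophenyl in place of 2-methylphenyl on an aromatic nitrogen. For the measured compounds named here, the one step that bears on changing this phenyl group is an at least 1.4-fold lower number from compound 1 to compound 2 (0.15 log units; that floor lies within the scatter), whose floor lies within the scatter. Going by the values given here, a nitro group brings no measured step of its own here. No step beyond the scatter is therefore expected, and compound 4 is estimated at 45000 nM, between 20000 nM and 100000 nM, a step of an at least 1.1-fold lower number from compound 1 to compound 4 (0.04 log units; that floor lies within the scatter) that is expected to stay near the limit.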

Compound 4, half-maximal inhibitory concentration: > 50000 nM
Compound 4 gave a limit, no number (the forecaster's own chance of this, stated with the estimate: 55%); middle value at least 1.1-fold (0.04 log units) from the limit.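

Compound 4 adds a nitro-bearing phenyl to the compounds that give only a limit, so 4-nitrophenyl on this aromatic nitrogen yields no number in this assay: the limit of > 50000 nM in this assay, at which 3 of the 4 values shown sit. The steps that connect it with compound 1 and compound 3 cannot be read, as both ends are limits. The one readable step is an at least 1.4-fold higher number from compound 2 to compound 4 (0.15 log units; that floor lies within the scatter), so 4-nitrophenyl is not shown to differ from 3-chlorophenyl beyond the scatter.

Going by these compounds, it remains open whether an amine or a carboxylic acid on this phenyl ring would give a clear number. On these data alone, how changes to the shared core would read out also remains open.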